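From 4-cyanophenoxy to 4-fluorophenyl at an assay limit

The source may report more compounds than this note shows. Statements on the series, on what has been measured and on what is new or still open speak of the compounds shown alone.

Of the compounds shown here, three sharing one core have been tested in an ADME assay on MRC5 cells (Homo sapiens) for cytotoxicity, read by fluorescence and resazurin assay, with a stated time of 3 days; on this read-out higher numbers stand for lower toxicity in this test and lower numbers for higher toxicity in this test. Compound 1 `O=C(Nc1cc(-c2ccccn2)n[nH]1)N1CCC(c2cccc(F)c2)CC1` gives > 64000 nM, which is a limit and not a number. Compound 2 `N#Cc1ccc(C2CCN(C(=O)Nc3cc(-c4ccccn4)n[nH]3)CC2)cc1` gives > 64000 nM, which is also a limit. Compound 3 `N#Cc1ccc(OC2CCN(C(=O)Nc3cc(-c4ccccn4)n[nH]3)CC2)cc1` gives > 63000 nM, again a limit, so it has no exact number to start from. The whole set therefore rests on two limits: the limit of > 63000 nM in this assay, at which 1 of the 3 values shown sits, and (the limit of > 64000 nM in this assay, at which 2 of the 3 values shown sit).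

The step followed here leads to compound 4 `O=C(Nc1cc(-c2ccccn2)n[nH]1)N1CCC(c2ccc(F)cc2)CC1`, with 4-fluorophenyl in place of 4-cyanophenoxy on a saturated ring carbon. Three measured steps change the group at this same carbon: a step that the two limits leave unreadable from compound 1 to compound 2, a step that the two limits leave unreadable from compound 1 to compound 3 and a step that the two limits leave unreadable from compound 2 to compound 3. None of them has a readable size, and none of the three compounds gives a value short of a limit. They offer no direction for the new change, so no step beyond the scatter is expected in this assay. The expected step is a step that the limit leaves unreadable from compound 3 to compound 4. The estimate for compound 4 is 64000 nM, with an expected range from 30000 nM to 100000 nM.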

Compound 4, half-maximal cytotoxic concentration: > 64000 nM
Compound 4 ended at the assay's limit; the forecaster's own chance of this, stated with the estimate: 85%; the middle value sits exactly at the limit.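

In this assay compound 4 gives > 64000 nM and this is a limit, not a number. Among the compounds shown here, no step from compound 1, compound 2 or compound 3 to compound 4 can be read. The compounds shown leave open at what concentration any of the four would turn toxic in this assay and whether the group on the saturated ring carbon changes that concentration.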